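Amino on compound 2: what the assay may show

The source may report more compounds than this note shows. Statements on the series, on what has been measured and on what is new or still open speak of the compounds shown alone.

Values in a functional assay on T-24 cells (Homo sapiens) for antiproliferative activity; on this read-out higher numbers stand for weaker inhibition and lower numbers for stronger inhibition:
- Compound 1 `N=C(N)N/N=C/c1cccc(C(N)=O)c1`: > 184000 nM, a limit
- Compound 2 `N=C(N)N/N=C/c1cccc(C(=N)N)n1`: 10100 nM
- Compound 3 `N=C(N)N/N=C/c1cccc(C(=N)NO)n1`: > 119000 nM, a limit

Of these three compounds, only compound 2 has a measured number, 10100 nM. The other two entries are limits, so compound 2 is the sole firm point of reference in this assay.

The next compound is compound 4 `N=C(NN)N/N=C/c1cccc(C(=N)N)n1`, which is built from compound 2 by one structural change: amino in place of hydrogen on an amine nitrogen. In words, amino takes the place of hydrogen on an amine nitrogen.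

Among the measured compounds shown here, one measured step bears on this change: an at least 11-fold higher number from compound 2 to compound 3 (1.07 log units; beyond the scatter). That step is large and lies beyond the scatter. It also replaces a hydrogen at a nitrogen, but the incoming group is hydroxy rather than amino, and the two changes do not fall on the same nitrogen. It is therefore a loose guide to direction and a poor guide to size.

A weaker result is expected, though by less than that measured step, and the expected change is a 2.5-fold higher number from compound 2 to compound 4 (0.39 log units; beyond the scatter). A result reported only as a limit would not be a surprise. For compound 4 the estimated value is 25000 nM, with an expected range from 6000 nM to 110000 nM.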

Compound 4, half-maximal inhibitory concentration: 83600 nM
Compound 4: middle estimate off by 3.3-fold (0.52 log units), on the low side; low and high end bracket the measured number.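

At this amine nitrogen, whose other neighbour is carbon with a double bond to nitrogen, amino in place of hydrogen gives an 8.3-fold higher number from compound 2 to compound 4 (0.92 log units; beyond the scatter) in this assay, so this one substitution weakens the result while compound 4 still returns a measured number. Unlike the step to compound 3, this step has a measured value at both ends, which fixes its size and does not merely set a lower bound. Compound 3 is reported only as a limit, and it carries its hydroxy on a different nitrogen: the limit of > 119000 nM in this assay, at which 1 of the 4 values shown sits.

Amino is the only group shown on this nitrogen, so it remains open whether a carbon group such as methyl or a longer chain such as ethyl, or an acetyl group, would give a step of similar size here. The compounds shown also offer no cause for the step, and they leave open whether it comes from the amino group itself or from any replacement of that hydrogen.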